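The source may hold more compounds than are shown below. What is called first, only, known or untested is meant among the compounds shown, and "the series" means these compounds.

In a functional assay on RAW264.7 cells (Mus musculus) for inhibition, read by fluorescence, with stated times of 1 h, 24 h and 30 min (on this read-out lower numbers stand for stronger inhibition and higher numbers for weaker inhibition), compound 3 `O=C(/C=C/c1ccccc1C(F)(F)F)c1ccc(O)cc1` gives > 10000 nM, which is a limit and not a number. Compound 1 `O=C(/C=C/c1ccccc1C(F)(F)F)c1ccccc1` gives > 10000 nM, also a limit. For compound 2 `O=C(/C=C/c1ccccc1C(F)(F)F)c1ccccc1O` the entry reads "not determined" (no result reported) and offers no result. For the measured compounds named here, the only measured step is a step that the two limits leave unreadable from compound 1 to compound 3 and so supplies no size to carry forward. Compound 4 `O=C(/C=C/c1ccccc1OC(F)(F)F)c1ccc(O)cc1` differs from compound 3 as follows: trifluoromethoxy in place of trifluoromethyl on an aromatic carbon and the trifluoromethoxy sits ortho to a large group. Resting on compound 3 with its limit > 10000 nM as the sole anchor, no step beyond the scatter is expected in this assay, and no direction can be given. The estimated step is a step that the limit leaves unreadable from compound 3 to compound 4 as the expected outcome. For compound 4 the estimate is 12000 nM, with an expected range from 4000 nM to 30000 nM in this assay.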

Compound 4, half-maximal inhibitory concentration: 1340 nM
Compound 4: middle estimate off by 9.0-fold (0.95 log units), on the high side; the measured number lies below the stated range.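

In this assay, for the compounds shown here, trifluoromethoxy in place of trifluoromethyl on an aromatic carbon, ortho to a large group, gives an at least 7.4-fold lower number from compound 3 to compound 4 (0.87 log units; beyond the scatter), the only step here with a readable size. Compound 1 and compound 3 give only limits, and the step between them cannot be read: the limit of > 10000 nM in this assay, at which 2 of the 4 values shown sit.

This one pair ties the change to a measurable inhibition on the core of compound 3, and no wider pattern follows from it. Going by these compounds, whether a methoxy or an amine at this place would do the same stays open. So does whether the same change would hold on the core of compound 1, which lacks the hydroxy.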